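A Fluoropyridine Isomer Awaits Its Cytotoxicity Reading

The source may hold more compounds than are shown below. What is called first, only, known or untested is meant among the compounds shown, and "the series" means these compounds.

In a functional assay on HCT-116 cells (Homo sapiens) for cytotoxicity, read by CellTiter-Glo (a lower number here means a stronger inhibitor, a higher number a weaker inhibitor), compound 1 `Fc1ccccc1[C@H](Nc1nnc(-c2c[nH]c3ncccc23)o1)C1CC1` gives 880 nM. Compound 2 `Fc1ncccc1[C@H](Nc1nnc(-c2c[nH]c3ncccc23)o1)C1CC1` gives 1800 nM, the higher of the two numbers, which makes it the weaker inhibitor of this pair. Compound 3 `Fc1cnccc1[C@H](Nc1nnc(-c2c[nH]c3ncccc23)o1)C1CC1` has not yet been measured. It has the same atoms as compound 2, joined differently: 3-fluoropyridin-4-yl in place of 2-fluoropyridin-3-yl on a saturated chain carbon bound to a nitrogen on an aromatic ring and a saturated ring carbon. On the saturated chain carbon, 3-fluoropyridin-4-yl stands in place of 2-fluoropyridin-3-yl.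

For the measured compounds named here, only one measured step bears on this change: a 2.0-fold higher number from compound 1 to compound 2 (0.31 log units; beyond the scatter), a modest move that came with 2-fluoropyridin-3-yl replacing 2-fluorophenyl. Its bearing is indirect, since that step swaps a phenyl ring for a pyridine ring, while compound 3 remains a fluoropyridine. Going by the values given here, no measurement yet compares two fluoropyridine isomers, so neither direction can be favoured in this assay. With the step to compound 2 only modest, a similarly small shift or less seems likely. The estimated change is a 1.1-fold lower number from compound 2 to compound 3 (0.05 log units; within the scatter), which means no expected step beyond the scatter. The expected value for compound 3 is 1600 nM, with an estimated range from 600 nM to 4500 nM.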

Compound 3, half-maximal inhibitory concentration: 5700 nM
Compound 3: the middle estimate sits 3.6-fold (0.55 log units) below what was measured; the whole stated range lies below it.
By their numbers in this assay, from the lowest: compound 1; then compound 2; then compound 3.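

In this assay, the step of a 3.2-fold higher number from compound 2 to compound 3 (0.50 log units; beyond the scatter) shows that this place on the saturated chain carbon responds to how the ring is arranged, not only to which atoms it holds: 2-fluoropyridin-3-yl and 3-fluoropyridin-4-yl have the same atoms and the same counts of hydrogen-bond donors and acceptors, yet they give different readings beyond the usual scatter. The earlier comparison could suggest only that replacing 2-fluorophenyl with one fluoropyridine weakens the compound, whereas a 6.5-fold higher number from compound 1 to compound 3 (0.81 log units; beyond the scatter) is a larger step than a 2.0-fold higher number from compound 1 to compound 2 (0.31 log units; beyond the scatter), so the size of that loss depends on which fluoropyridine is used. Nothing available here explains why the two isomers differ.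

Among these three compounds, both fluoropyridines are weaker than the 2-fluorophenyl compound, but this says little about other rings at this place. Open questions include how a pyridine ring without fluorine would compare, and whether a chlorine atom or a methoxy group in place of the fluorine would give the same order.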